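Isobutyl in Place of Isopropyl on a Shared Core

The compounds below may be only part of what the source reports. "The series", "measured", "known", "first", "only" and "open" are said of these compounds alone.

Of the compounds shown here, three with a shared core have been tested in an ADME assay on Jurkat cells (Homo sapiens) for cytotoxicity, read by MTT assay, with a stated time of 72 h; on this read-out higher numbers stand for weaker inhibition and lower numbers for stronger inhibition. Compound 1 (`NC(=O)c1cnc(Oc2ccc3c(c2)B(O)OC3)cn1`), with amino on the carbonyl carbon, gives 48200 nM. Compound 2 (`CCOC(=O)c1cnc(Oc2ccc3c(c2)B(O)OC3)cn1`), with ethoxy there, gives 16800 nM. For compound 3 (`CC(C)OC(=O)c1cnc(Oc2ccc3c(c2)B(O)OC3)cn1`), with isopropoxy there, the result is a limit and not a number: > 100000 nM.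

Compound 4 (`CC(C)COC(=O)c1cnc(Oc2ccc3c(c2)B(O)OC3)cn1`) has isobutyl in place of isopropyl on an oxygen next to a carbonyl group. The closest measured change is the added methyl on the same chain, an at least 5.9-fold higher number from compound 2 to compound 3 (0.77 log units; beyond the scatter). Swaps on the carbonyl carbon moved the number both ways, with a 2.9-fold lower number from compound 1 to compound 2 (0.46 log units; beyond the scatter) and an at least 2.0-fold higher number from compound 1 to compound 3 (0.31 log units; beyond the scatter). These steps give no single direction for a longer chain, but the other two compounds both gave numbers, so a modest move to a lower number is expected in this assay, though another limit remains possible. The expected change is an at least 2.0-fold lower number from compound 3 to compound 4 (0.30 log units; that floor lies within the scatter). Compound 4 is estimated at 50000 nM, within a range of 15000 nM to 100000 nM.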

Compound 4, half-maximal inhibitory concentration: 17600 nM
Beside the measured number, compound 4's estimate is 2.8-fold (0.45 log units) above it; the measured number falls inside the stated range.
By their numbers in this assay, from the lowest: compounds 2 and 4 (each within the scatter of the next); then compound 1. At a limit, above all of these: compound 3.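

In this assay, the ester chain on this oxygen does not push the number up simply by growing: isobutyl in place of isopropyl gives an at least 5.6-fold lower number from compound 3 to compound 4 (0.75 log units; beyond the scatter). The ethyl ester and the isobutyl ester sit level, with a 1.0-fold higher number from compound 2 to compound 4 (0.02 log units; within the scatter), and both differ from the amide in the same direction, as isobutoxy in place of amino gives a 2.7-fold lower number from compound 1 to compound 4 (0.44 log units; beyond the scatter). The first step is only a floor, as compound 3 gives a limit and not a number: the limit of > 100000 nM in this assay, at which 1 of the 4 values shown sits.

Still open, from the compounds shown here alone, is whether the limit belongs to isopropyl alone or extends to other chains branched at the carbon bound to the oxygen, such as tert-butyl. A longer straight chain such as butyl, or the free carboxylic acid, could also show how far the level shared by compound 2 and compound 4 extends.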